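Swapping the aryl group on a weakly cytotoxic urea scaffold

This account rests on a few compounds, and the source may have more. Where it says the series, first, only, none or still open, it means among the compounds named here.

Compound 1 `CN(C)CCn1cnnc1-c1cc(Oc2ccc(NC(=O)N/N=C/c3cccc(Cl)c3Cl)cc2F)ccn1` was tested in an ADME assay on WI-38 cells (Homo sapiens) for cytotoxicity, read by MTT assay, with a stated time of 72 h (a lower number here means a stronger inhibitor, a higher number a weaker inhibitor), where compound 1 gives 6130 nM. For the measured compounds named here, that is the highest number among the two compounds measured so far; compound 2 `CN(C)CCn1cnnc1-c1cc(Oc2ccc(NC(=O)N/N=C/c3cc(C(C)(C)C)cc(C(C)(C)C)c3O)cc2F)ccn1` gives 2350 nM in this assay, a difference beyond the usual scatter. Compound 3 `CN(C)CCn1cnnc1-c1cc(Oc2ccc(NC(=O)N/N=C/c3c[nH]c4ccccc34)cc2F)ccn1` has not been measured. It differs from compound 1 by 1H-indol-3-yl in place of 2,3-dichlorophenyl on a carbon with a double bond to nitrogen. Since no single-change comparison has been measured, the step from compound 1 to compound 3 is expected to be small, a 1.2-fold lower number from compound 1 to compound 3 (0.09 log units; within the scatter), and not clearly beyond the scatter in either direction. Compound 3 is estimated at 5000 nM, with a likely range from 2000 nM to 14000 nM.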

Compound 3, half-maximal inhibitory concentration: 3620 nM
For compound 3 the middle estimate is 1.4-fold (0.14 log units) above the measured one; the measured number falls inside the stated range.
By their numbers in this assay, from the lowest: compounds 2, 3 and 1 (each within the scatter of the next, the first and the last beyond it).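

For the compounds shown here, this is the first single-change comparison at this position, on a carbon with a double bond to nitrogen. In this assay, the step of a 1.7-fold lower number from compound 1 to compound 3 (0.23 log units; within the scatter) shows that 1H-indol-3-yl can replace 2,3-dichlorophenyl without moving the number beyond the scatter, even though the entering group adds a five-membered ring and a hydrogen-bond donor. No supporting evidence bears on why the two groups read alike. Still open, from the compounds shown here alone, is whether a group of another kind here, such as a carboxylic acid or a longer chain ending in an amine, would shift the number beyond the scatter.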